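Working notes: step from compound 3 to compound 4

The source may hold more compounds than are shown below. What is called first, only, known or untested is meant among the compounds shown, and "the series" means these compounds.

Of the compounds shown here, three sharing one core have been measured. Compound 1 `COc1cc(NC(=O)Nc2cc(Nc3ccc(C)c(C)c3)ncn2)cc(OC)c1` gives 29.5% in a functional assay on NCI-H520 cells (Homo sapiens) for inhibition, read by MTT assay, with a stated time of 48 h, tested at 10 uM; a lower number here means less inhibition, a higher number more inhibition at the concentration tested (going by the name of the read-out). Compound 2 `COc1cc(NC(=O)Nc2cc(Nc3ccc(C)c(F)c3)ncn2)cc(OC)c1` gives 30.6% in this assay, and compound 3 `COc1cc(NC(=O)Nc2cc(Nc3cc(F)ccc3OC)ncn2)cc(OC)c1` gives 38% in this assay. Compound 3 gives the largest of the three numbers, but the steps of a number 8.5 percentage points higher from compound 1 to compound 3 (within the scatter) and a number 7.4 percentage points higher from compound 2 to compound 3 (within the scatter) are both within the scatter, as is a number 1.1 percentage points higher from compound 1 to compound 2 (within the scatter), so the three compounds cannot be separated on these numbers.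

Compound 4 `COc1cc(NC(=O)Nc2cc(Nc3cc(C(F)(F)F)ccc3OC)ncn2)cc(OC)c1` is not yet measured. It differs from compound 3 by trifluoromethyl in place of fluoro on an aromatic carbon. For the measured compounds named here, the only measured step that changes a single substituent on an aromatic carbon is a number 1.1 percentage points higher from compound 1 to compound 2 (within the scatter), and it stayed within the scatter. No measured step introduces a trifluoromethyl group, so nothing shown points to a change beyond the scatter in this assay.

Compound 4 is therefore expected to give about 38% in this assay, with a range from 22% to 54%. The expected step is no change at the digits printed from compound 3 to compound 4 (within the scatter), within the scatter.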

Compound 4, a percentage reported as inhibition, at one concentration (the size of the read-out at that concentration, not a potency): 63%
Compound 4: the middle estimate sits 25 percentage points below what was measured; measured number above the stated range.
By their numbers in this assay, from the lowest: compounds 1, 2 and 3 (each within the scatter of the next); then compound 4.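

Trifluoromethyl in place of fluoro, on an aromatic carbon meta to a large group and para to a methoxy group, gives in this assay a number 25 percentage points higher from compound 3 to compound 4 (beyond the scatter). This is the only step shown that leaves the scatter, so the read-out does respond to a change on this aniline-type ring, which compound 1, compound 2 and compound 3 could not show among themselves. Nothing available bears on the reason for this step.

With only fluoro and trifluoromethyl shown at this position, it remains open whether a nitrile, a chlorine or a methyl there would read like compound 3 or like compound 4. Going by these compounds, it is also open whether the same exchange holds when the methoxy group is replaced, and since the read-out comes from a single concentration, it gives no potency.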